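Cytotoxicity notes on a benzylimidazole anilinoester series

A few compounds are considered here, and "the series" means these few. Any claim that something is new, unique, unknown or untested is made for them only; others in the source may bear on it.

Measured compounds:
- compound 1 `COC(=O)c1ccc(NCc2cncn2Cc2cccc(-c3ccccc3)c2)cc1-c1ccccc1`: "not determined" (no result reported) in the cytotoxicity assay
- compound 2 `COC(=O)c1ccc(NCc2cncn2Cc2ccccc2C)cc1-c1ccccc1`: 10000 nM

In a toxicity assay on NIH3T3 cells (Mus musculus) for cytotoxicity, read by resazurin assay (a higher number here means that more compound is needed for the effect, a lower number that less compound is needed), compound 1 is reported as "not determined" (no result reported), so it contributes no number. In this assay, for the measured compounds named here, compound 2 gives 10000 nM; with compound 1 reporting nothing, this is the only number in hand, and compound 2 therefore stands alone as the single reference point for the series. Going by the values given here, no step between two measured compounds exists, so nothing is yet known about how any structural change moves the read-out.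

Compound 3 `COC(=O)c1ccc(NCc2cncn2Cc2ccccc2Br)cc1-c1ccccc1` has not been measured. It differs from compound 2 by bromo in place of methyl on an aromatic carbon. The change swaps one heavy atom for one heavy atom on an aromatic carbon of a six-membered aromatic ring of carbon only, with no change in ring count, hydrogen-bond donors or acceptors, or charge. Among the compounds with values here, with only one number and no measured step to go on, the expectation is that the step from compound 2 to compound 3 stays within the usual scatter, with no direction implied, and the estimated step is no change at the digits printed from compound 2 to compound 3 (within the scatter). Compound 3 is accordingly estimated at 10000 nM in this assay, with an expected range from 3000 nM to 30000 nM.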

Compound 3, half-maximal effective concentration: 10000 nM
Compound 3: middle estimate and measured number agree at the digits printed; the measured number falls inside the stated range.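

In this assay, for the compounds shown here, the exchange of 2-methylbenzyl for 2-bromobenzyl gives the first readable step (no change at the digits printed from compound 2 to compound 3 (within the scatter)), so compound 2 is no longer a lone reference point. At this place, on an aromatic carbon ortho to a large group, methyl and bromo cannot be told apart by this read-out, although this single pair supports no wider rule about other groups there or about other places on the benzyl ring. Nothing in hand accounts for the two groups reading alike.

Going by these compounds alone, compound 1 carries no number, so no step involving it can be read, and the effect of a larger group on the benzyl ring stays unknown. Also open, as far as these compounds go, is whether an amine, a carboxylic acid or a longer chain at the same place would move the read-out beyond the scatter, and whether a free carboxylic acid in place of the methyl ester on the shared core would do so.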